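The compounds below may be only part of what the source reports. "The series", "measured", "known", "first", "only" and "open" are said of these compounds alone.

Measured so far in an assay on striatum for inhibition of sodium-dependent dopamine transporter (Rattus norvegicus); on this read-out lower numbers stand for stronger inhibition and higher numbers for weaker inhibition:
compound 1 `c1ccc(C(c2ccccc2)[C@@H]2CC[C@H](NCc3ccc[nH]3)CO2)cc1` gives 43.2 nM
compound 2 `c1ccc(C(c2ccccc2)[C@@H]2CC[C@H](NCc3cccs3)CO2)cc1` gives 41.4 nM
compound 3 `c1ccc(C(c2ccccc2)[C@@H]2CC[C@H](NCc3ccco3)CO2)cc1` gives 110 nM

Compound 3 stands at the highest of the three numbers and is the weakest binder shown: the steps of a 2.5-fold higher number from compound 1 to compound 3 (0.41 log units; beyond the scatter) and a 2.7-fold higher number from compound 2 to compound 3 (0.42 log units; beyond the scatter) both run beyond the scatter, whereas the step of a 1.0-fold lower number from compound 1 to compound 2 (0.02 log units; within the scatter) stays within it.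

Compound 4 `c1ccc(C(c2ccccc2)[C@@H]2CC[C@H](NCc3ccncc3)CO2)cc1` differs from compound 3 in one place: pyridin-4-yl in place of furan-2-yl on a saturated chain carbon bound to an amine nitrogen. Going by the values given here, none of the measured steps covers this exchange. Among the compounds with values here, the two steps into compound 3 show only that compound 3, carrying furan-2-yl at this carbon, comes out higher than compound 1 with pyrrol-2-yl or compound 2 with thiophen-2-yl; no measured pair swaps a five-membered ring for a six-membered one, so the direction of the new step is open. Because compound 3 sits at 110 nM with both neighbours a modest step below, compound 4 is expected to land near that level or somewhat under it, with no firm call beyond the scatter; the estimated step is a 1.4-fold lower number from compound 3 to compound 4 (0.14 log units; within the scatter). Compound 4 is accordingly estimated at 80 nM, within a range of 30 nM to 250 nM.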

Compound 4, inhibition constant: 28.3 nM
Compound 4: middle estimate off by 2.8-fold (0.45 log units), on the high side; the measured number lies below the stated range.
By their numbers in this assay, from the lowest: compounds 4, 2 and 1 (each within the scatter of the next); then compound 3.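

In this assay the exchange of furan-2-yl for pyridin-4-yl gives a 3.9-fold lower number from compound 3 to compound 4 (0.59 log units; beyond the scatter) and is the only kind of step shown that replaces a five-membered aromatic ring with a six-membered one on a saturated chain carbon bound to an amine nitrogen. Set against the other two five-membered rings, pyridin-4-yl gives a 1.5-fold lower number from compound 2 to compound 4 (0.17 log units; within the scatter) and a 1.5-fold lower number from compound 1 to compound 4 (0.18 log units; within the scatter) and both steps stay within the scatter, so at this carbon the six-membered ring reads the same as thiophen-2-yl and 1H-pyrrol-2-yl, and among the four compounds only furan-2-yl stands apart, with compound 3 at the highest number. Ring size therefore does not sort these four compounds, since five-membered rings fall on both sides of the gap, and nothing available explains why furan-2-yl differs from the others.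

From the compounds shown here alone, only pyridin-4-yl represents the six-membered rings here, so it remains open whether pyridin-3-yl, pyridin-2-yl or a plain phenyl ring would give a similar number at this carbon. Also open, going by these compounds, is how a longer chain between the amine nitrogen and the ring would read on this measure.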